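Dropping a Hydroxy Group: What Happens to Growth Inhibition

A few compounds are considered here, and "the series" means these few. Any claim that something is new, unique, unknown or untested is made for them only; others in the source may bear on it.

Two amides built on a shared core have been measured. In a functional assay on ACHN cells (Homo sapiens) for cytotoxicity, read by sulforhodamine B assay, with a stated time of 72 h (a higher number here means a weaker inhibitor of growth, a lower number a stronger inhibitor of growth), compound 1 `COc1ccc(NC(=O)C2CCc3ccccc3N2)cc1` gives 38000 nM, while compound 2 `O=C(Nc1ccccc1O)C1CCc2ccccc2N1` gives 3990 nM, the lower of the two numbers and clearly apart from compound 1. Compound 3 `O=C(Nc1ccccc1)C1CCc2ccccc2N1` is not yet measured; it differs from compound 2 by hydrogen in place of hydroxy on an aromatic carbon. For the measured compounds named here, no measured pair shows this exact change, so only an expectation is possible: in this assay the change is expected to bring a 3.0-fold higher number from compound 2 to compound 3 (0.48 log units; beyond the scatter), a loss of potency. Compound 3 is therefore estimated at 12000 nM, with a likely range from 3000 nM to 50000 nM.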

Compound 3, concentration for 50% growth inhibition: 72900 nM
For compound 3 the middle estimate is 6.1-fold (0.78 log units) below the measured one; the measured number lies above the stated range.
By their numbers in this assay, from the lowest: compound 2; then compounds 1 and 3 (each within the scatter of the next).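

In this assay hydrogen in place of hydroxy ortho to a large group brings an 18-fold higher number from compound 2 to compound 3 (1.26 log units; beyond the scatter) and so marks a large step, which shows that the lower number of compound 2 depends on this hydroxy. The methoxy group of compound 1 shows no such dependence, since hydrogen in its place brings a 1.9-fold higher number from compound 1 to compound 3 (0.28 log units; within the scatter) and stays within the scatter. Nothing measured here gives a reason for the size of the hydroxy step. Still open, as far as these compounds go, is whether an amine or a fluorine atom in that same place would keep the number of compound 2.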